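A few compounds are considered here, and "the series" means these few. Any claim that something is new, unique, unknown or untested is made for them only; others in the source may bear on it.

Measured so far in an assay on membranes from HeLa cells for displacement of a labelled ligand from adenosine receptor A3 (Homo sapiens), read by scintillation counting, with a stated time of 180 min, tested at 1 uM; a lower number here means less inhibition, a higher number more inhibition at the concentration tested (going by the name of the read-out):
compound 1 `CCCOC(=O)C1=C(C)NC(=O)NC1c1ccco1` gives 3%
compound 2 `CC1=C(C(=O)CC(C)C)C(c2ccco2)NC(=O)N1` gives 31%
compound 3 `CC1=C(C(=O)OC2CCC2)C(c2ccco2)NC(=O)N1` gives 1%

Compound 3 holds the lowest of the three numbers, though its gap to compound 1 is within the scatter (a number 2 percentage points lower from compound 1 to compound 3 (within the scatter)); only compound 2 stands apart (a number 30 percentage points lower from compound 2 to compound 3 (beyond the scatter)).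

Compound 4 `CC1=C(C(=O)OC2CCCC2)C(c2ccco2)NC(=O)N1` differs from compound 3 as follows: cyclopentyl in place of cyclobutyl on an oxygen next to a carbonyl group. Within the data shown here, the one step that bears on it is the change at the same oxygen next to a carbonyl group, propyl to cyclobutyl, which gave a number 2 percentage points lower from compound 1 to compound 3 (within the scatter). The larger steps of a number 28 percentage points higher from compound 1 to compound 2 (beyond the scatter) and a number 30 percentage points lower from compound 2 to compound 3 (beyond the scatter) concern the carbonyl carbon itself and do not apply here. No step beyond the scatter is therefore expected for compound 4 (a number 4 percentage points higher from compound 3 to compound 4 (within the scatter)). Compound 4 is estimated at 5%, range -8% to 20%.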

Compound 4, a percentage reported as inhibition, at one concentration (the size of the read-out at that concentration, not a potency): 14%
Compound 4: the middle estimate sits 9 percentage points below what was measured; low and high end bracket the measured number.
By their numbers in this assay, from the lowest: compounds 3 and 1 (each within the scatter of the next); then compound 4; then compound 2.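

Ring size on an oxygen next to a carbonyl group does register: cyclopentyl in place of cyclobutyl gives (a number 13 percentage points higher from compound 3 to compound 4 (beyond the scatter)), whereas propyl to cyclobutyl had stayed within the scatter (a number 2 percentage points lower from compound 1 to compound 3 (within the scatter)). Cyclopentyl also separates from propyl (a number 11 percentage points higher from compound 1 to compound 4 (beyond the scatter)), yet cyclopentyloxy does not close the gap to isobutyl on the carbonyl carbon (a number 17 percentage points lower from compound 2 to compound 4 (beyond the scatter)). No measurement at hand accounts for the rise with cyclopentyl.

Open, as far as these compounds go, is whether cyclohexyl or benzyl on the same oxygen would carry the number further. Also open, from the compounds shown here alone, is whether any group on that oxygen can match isobutyl on the carbonyl carbon.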